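The source may report more compounds than this note shows. Statements on the series, on what has been measured and on what is new or still open speak of the compounds shown alone.

Compound 1 `Cc1ncc([N+](=O)[O-])n1CC(O)CSC(=S)N1CCN(c2ccccc2F)CC1` and compound 2 `Cc1ncc([N+](=O)[O-])n1CC(O)CSC(=S)N1CCN(c2cccc(Cl)c2)CC1` share one core and differ at a single place (3-chlorophenyl in place of 2-fluorophenyl on an amine nitrogen in a ring). In a toxicity assay on HeLa cells (Homo sapiens) for cytotoxicity, read by MTT assay, with a stated time of 24 h (a lower number here means a stronger inhibitor, a higher number a weaker inhibitor), compound 1 gives 3240000 nM, while compound 2 gives 1080000 nM, so that change produced a 3.0-fold lower number from compound 1 to compound 2 (0.48 log units; beyond the scatter). Compound 3 `Cc1ncc([N+](=O)[O-])n1CC(O)CN1CCN(c2ccccc2F)CC1` rests on a different core, and the difference between the two cores is not broken down here. In this assay compound 3 yields only a limit of the assay, > 5000000 nM. Compound 4 `Cc1ncc([N+](=O)[O-])n1CC(O)CN1CCN(c2cccc(Cl)c2)CC1` carries the same kind of change on the core of compound 3 (3-chlorophenyl in place of 2-fluorophenyl on an amine nitrogen in a ring), at a place described in the same words. The expected step is an at least 1.6-fold lower number from compound 3 to compound 4 (0.22 log units; that floor lies within the scatter), resting on the measured step of a 3.0-fold lower number from compound 1 to compound 2 (0.48 log units; beyond the scatter), although compound 3 already sits at the limit (the limit of > 5000000 nM in this assay, at which 1 of the 3 values shown sits), so a limit may be reported again. Compound 4 is estimated at 3000000 nM, between 1000000 nM and 9000000 nM.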

Compound 4, half-maximal inhibitory concentration: 1440000 nM
Compound 4: the middle estimate sits 2.1-fold (0.32 log units) above what was measured; measured number inside the range.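

In this assay, 3-chlorophenyl in place of 2-fluorophenyl gives an at least 3.4-fold lower number from compound 3 to compound 4 (0.54 log units; beyond the scatter), so the change lowers the number on this core too, and the direction carries over between these two cores: the same change on two cores in this assay, a 3.0-fold lower number (0.48 log units; beyond the scatter) from compound 1 to compound 2 and an at least 3.4-fold lower number (0.54 log units; beyond the scatter) from compound 3 to compound 4; the limit leaves it open whether they differ. As far as these compounds go, compound 3 gives > 5000000 nM, which is a limit of the assay and not an exact number, so the true size of this step stays unknown: the limit of > 5000000 nM in this assay, at which 1 of the 4 values shown sits. Two cores also cannot show that the change would act the same way on any other core in the series.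

This change replaces the halogen and moves it in one go, so the compounds shown leave open which of the two accounts for the step. A 2-chlorophenyl, a 3-fluorophenyl or a plain phenyl on these cores would help separate them.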